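Swapping a Hydroxycyclobutyl for a Carbamoyl Cyclobutyl Amide

The compounds below may be only part of what the source reports. "The series", "measured", "known", "first", "only" and "open" are said of these compounds alone.

Compound 1 `N#Cc1cnc(NCc2cnccc2C(F)(F)F)cc1N[C@H]1C[C@H](O)C1` was tested in an assay on isolated protein for inhibition of protein kinase C delta type (Homo sapiens), read by TR-FRET, with a stated time of 2 h (a lower number here means a stronger inhibitor, a higher number a weaker inhibitor), and gave > 10000 nM, which is a limit of the measurement rather than a number. Compound 2 `N#Cc1cnc(NCc2ccccc2)cc1N[C@H]1CC[C@@H](O)CC1` likewise gave only > 10000 nM, a limit. So compound 1 sits at the limit of > 10000 nM in this assay, at which 2 of the 3 values shown sit, and only compound 3 `CC(C)(C)Oc1ncncc1CNc1cc(N[C@H]2CC[C@@H](O)CC2)c(C#N)cn1` yields a number, 200 nM. Compound 4 `CC1(C)[C@@H](C(N)=O)C[C@H]1Nc1cc(NCc2cnccc2C(F)(F)F)ncc1C#N` has not been measured; it differs from compound 1 by 3-carbamoyl-2,2-dimethylcyclobutyl in place of 3-hydroxycyclobutyl on a nitrogen on an aromatic ring. For the measured compounds named here, with no measured step of this kind to lean on, the expected change from compound 1 to compound 4 is an at least 3.3-fold lower number from compound 1 to compound 4 (0.52 log units; beyond the scatter), a move toward stronger inhibition, though uncertain in size. For compound 4 the estimate is 3000 nM, within 300 nM to 30000 nM.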

Compound 4, half-maximal inhibitory concentration: 160 nM
Compound 4: the middle estimate sits 19-fold (1.27 log units) above what was measured, outside the stated range (below it).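

For the compounds shown here, compounds measured before this one offered no step at this position; here, on a nitrogen on an aromatic ring, 3-carbamoyl-2,2-dimethylcyclobutyl in place of 3-hydroxycyclobutyl gives an at least 62-fold lower number from compound 1 to compound 4 (1.79 log units; beyond the scatter) in this assay. The change at this one place is enough to bring compound 4 off the limit held by compound 1. The full size of the step stays unknown because compound 1 gives only a limit: the limit of > 10000 nM in this assay, at which 2 of the 4 values shown sit.

From the compounds shown here alone, it remains open whether the carbamoyl or the 2,2-dimethyl part carries this step. A 3-carbamoylcyclobutyl without the methyl groups, or a 3-aminocyclobutyl, could separate the contributions.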